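Aryl replacement at the former bromo position: compound 4

The compounds below may be only part of what the source reports. "The series", "measured", "known", "first", "only" and "open" are said of these compounds alone.

Compound 1 `Brc1cn2ccnc2c(-c2ccc3ncn(C4CCCCC4)c3c2)n1` gives 10.2% in a functional assay on SK-MEL-2 cells (Homo sapiens) for inhibition, read by sulforhodamine B assay, with a stated time of 48 h, tested at 10 uM; a higher number here means more inhibition at the concentration tested (going by the name of the read-out), a lower number less inhibition. Compound 2 `c1ccc(-c2cn3ccnc3c(-c3ccc4ncn(C5CCCCC5)c4c3)n2)cc1` gives 16.5%, and compound 3 `c1ccc2c(-c3cn4ccnc4c(-c4ccc5ncn(C6CCCCC6)c5c4)n3)cccc2c1` gives 2.3%, the lowest of the three numbers; a number 7.9 percentage points lower from compound 1 to compound 3 (within the scatter), whereas a number 14.2 percentage points lower from compound 2 to compound 3 (beyond the scatter). Compound 4 `Fc1ccc(-c2cn3ccnc3c(-c3ccc4ncn(C5CCCCC5)c4c3)n2)cc1` differs from compound 3 by 4-fluorophenyl in place of naphthalen-1-yl on an aromatic carbon. The step from compound 2 to compound 3 bears on this most directly, as compound 4 returns to a single six-membered ring; the step of a number 6.3 percentage points higher from compound 1 to compound 2 (within the scatter) adds little. Compound 4 is therefore expected to move back toward the level of compound 2, an estimated a number 11.7 percentage points higher from compound 3 to compound 4 (beyond the scatter) in the direction of more inhibition. The estimate for compound 4 is 14%, with a range from 4% to 26%.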

Compound 4, a percentage reported as inhibition, at one concentration (the size of the read-out at that concentration, not a potency): 9.82%
Compound 4: middle estimate off by 4.2 percentage points, on the high side, and the stated range covers the measured number.
By their numbers in this assay, from the lowest: compounds 3, 4, 1 and 2 (each within the scatter of the next, the first and the last beyond it).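

In this assay the new compound gives a number 7.5 percentage points higher from compound 3 to compound 4 (within the scatter) with 4-fluorophenyl in place of naphthalen-1-yl, a number 6.7 percentage points lower from compound 2 to compound 4 (within the scatter) with fluoro in place of hydrogen and a number 0.4 percentage points lower from compound 1 to compound 4 (within the scatter) with 4-fluorophenyl in place of bromo. Compound 4 thus separates from none of the other three at this position, although compound 2 and compound 3 lie beyond the scatter of each other. No measurement to hand accounts for these numbers. On these data alone, whether an amine or a carboxylic acid on this aromatic carbon would give a number beyond the scatter of all four compounds stays open.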